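Compound 4 and the limit of the MRC5 assay

The compounds below may be only part of what the source reports. "The series", "measured", "known", "first", "only" and "open" are said of these compounds alone.

Measured in an ADME assay on MRC5 cells (Homo sapiens) for cytotoxicity, read by neutral red uptake; a lower number here means that less compound is tolerated, a higher number that more compound is tolerated:
- Compound 1 `COc1ccc(CSc2nc3ccccc3c(=O)[nH]2)cc1`: > 64000 nM, a limit.
- Compound 2 `O=c1[nH]c(SCc2ccc([N+](=O)[O-])cc2)nc2ccccc12`: > 64000 nM, a limit.
- Compound 3 `O=c1[nH]c(SCc2cc([N+](=O)[O-])cc([N+](=O)[O-])c2)nc2ccc(Br)cc12`: > 64000 nM, a limit.

None of these three entries is a number. Among the measured compounds shown here, the series so far shows one thing only: the limit of > 64000 nM in this assay, at which 3 of the 3 values shown sit. Compound 3 therefore has no exact place in the series, and it stands at > 64000 nM, which is a limit.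

Compound 4 `CN1CCN(c2ccc3nc(SCc4cc([N+](=O)[O-])cc([N+](=O)[O-])c4)[nH]c(=O)c3c2)CC1` carries 4-methylpiperazin-1-yl in place of bromo on an aromatic carbon of the shared core: 4-methylpiperazin-1-yl in place of bromo on an aromatic carbon. For the measured compounds named here, the only measured step, a step that the two limits leave unreadable from compound 1 to compound 2, is nitro in place of methoxy on an aromatic carbon. It involves neither group in the present change and gives no size to carry over.

Going by the values given here, the data thus fix no step for this change, and the expectation stays close to the limit, with some room on the lower side in this assay. The expected step is an at least 1.4-fold lower number from compound 3 to compound 4 (0.15 log units; that floor lies within the scatter). Compound 4 is expected at 45000 nM, with an estimated range from 14000 nM to 64000 nM.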

Compound 4, half-maximal cytotoxic concentration: 49000 nM
Compound 4: middle estimate off by 1.1-fold (0.04 log units), on the low side; the measured number falls inside the stated range.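

In this assay, compound 4 is the only entry that reads as a number rather than a limit, and the rest of the series stays at the ceiling: the limit of > 64000 nM in this assay, at which 3 of the 4 values shown sit.

At this aromatic carbon of the shared core, putting 4-methylpiperazin-1-yl in place of bromo gives an at least 1.3-fold lower number from compound 3 to compound 4 (0.11 log units; that floor lies within the scatter). This is a floor and not a size, so the change is not yet shown to lower the number beyond the usual scatter, although the true step could be larger.

The compounds shown leave open whether another group at this place, such as morpholine, piperidine or a simple primary amine, would also give a number rather than a limit. They also leave open whether 4-methylpiperazin-1-yl would do so if methoxy replaced the nitro groups.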